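Methoxy on the Pyridine Ring of a Fluorinated Benzimidazole

The source may report more compounds than this note shows. Statements on the series, on what has been measured and on what is new or still open speak of the compounds shown alone.

Compound 1 `Fc1cc2nc(-c3cccnc3)n(C3CC3)c2cc1F` is the stronger of the two measured compounds here. In an assay on V79 cells for inhibition of cytochrome P450 11B2, mitochondrial (Homo sapiens), read by HTRF, with a stated time of 1 h (a higher number here means a weaker inhibitor, a lower number a stronger inhibitor), compound 1 gives 2.1 nM. Compound 2 `Fc1ccc2c(c1)nc(-c1cccnc1)n2C1CC1` differs from it in one place, with hydrogen in place of fluoro on an aromatic carbon, and in this assay compound 2 gives 28 nM. That single change produced a 13-fold higher number from compound 1 to compound 2 (1.12 log units; beyond the scatter), so compound 1 stands with the lowest of the two numbers, and its nearest neighbour is well separated from it.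

Compound 3 `COc1cncc(-c2nc3cc(F)c(F)cc3n2C2CC2)c1` keeps both fluoro groups of compound 1 and changes a different part of the molecule: methoxy in place of hydrogen on an aromatic carbon. Going by the values given here, the only measured step, from compound 1 to compound 2, concerns a fluoro on the other ring and does not touch the six-membered aromatic ring with one nitrogen, so nothing measured speaks directly to this change. With no guide, the expectation is a modest step at most in this assay, of a 1.7-fold higher number from compound 1 to compound 3 (0.22 log units; within the scatter), in either direction or none beyond the scatter. Compound 3 is therefore estimated at 3.5 nM, within a range of 1 nM to 12 nM.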

Compound 3, half-maximal inhibitory concentration: 0.4 nM
Compound 3: the middle estimate sits 8.8-fold (0.94 log units) above what was measured; the whole stated range lies above it.
By their numbers in this assay, from the lowest: compound 3; then compound 1; then compound 2.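

Before this result, the only measured step lay on the ring carrying the fluoro groups, so nothing showed how the six-membered aromatic ring with 1 nitrogen would respond to an added group. In this assay, placing methoxy on an aromatic carbon of that ring, two atoms from the ring nitrogen and meta to a large group, gives a 5.3-fold lower number from compound 1 to compound 3 (0.72 log units; beyond the scatter), which shows that this position accepts a group of 2 heavy atoms and that the number falls beyond the usual scatter. Nothing measured here explains this fall, so it cannot be tied to any particular feature of the methoxy group.

One methoxy at one position cannot show whether the lower number depends on the oxygen, the added carbon or the group as a whole; a hydroxy, a methyl or an ethoxy on this same carbon would help to separate these possibilities. Going by these compounds, it also remains open whether methoxy would have a similar effect at other carbons of this ring, or on compound 2, which has hydrogen in place of one fluoro.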